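Fluoro for hydrogen on the pyridine of compound 2

The source may hold more compounds than are shown below. What is called first, only, known or untested is meant among the compounds shown, and "the series" means these compounds.

In a physicochemical assay for solubility, using the shake flask method, in phosphate buffer, measured as kinetic solubility, with a stated time of 20 h, at pH 6.5 (on this read-out lower numbers stand for lower solubility and higher numbers for higher solubility), compound 1 `COc1ccnc(Nc2cc3[nH]c(-c4cccc(C(F)(F)F)c4)nc3cn2)c1` gives < 5000 nM as a limit. Compound 2 `Fc1ccc(Nc2cc3[nH]c(-c4cccc(C(F)(F)F)c4)nc3cn2)nc1` gives < 5000 nM as a limit too. Compound 2 therefore stands at the limit of < 5000 nM in this assay, at which 2 of the 2 values shown sit, and has no exact number. Going by the values given here, the only measured step is a step that the two limits leave unreadable from compound 1 to compound 2 and so offers no size to carry forward. Compound 3 `Fc1cnc(Nc2cc3[nH]c(-c4cccc(C(F)(F)F)c4)nc3cn2)c(F)c1` follows from compound 2 through fluoro in place of hydrogen on an aromatic carbon with fluoro in place of hydrogen on an aromatic carbon. The expected move is a step that the limit leaves unreadable from compound 2 to compound 3 and none beyond the scatter is anticipated. In this assay compound 3 is estimated at 3500 nM with a range from 1000 nM to 8000 nM as the expected bounds.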

Compound 3, solubility: < 5000 nM
Compound 3 ended at the assay's limit (the forecaster's own chance of this, stated with the estimate: 80%); the middle value does not contradict the limit.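

No step can be read among compound 1, compound 2 and compound 3, because each gives only a limit and not a number: the limit of < 5000 nM in this assay, at which 3 of the 3 values shown sit.

The compounds shown leave open their exact solubility, and so whether fluoro in place of hydrogen changes it at all.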